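Swapping the amide ring and lengthening the chain

A few compounds are considered here, and "the series" means these few. Any claim that something is new, unique, unknown or untested is made for them only; others in the source may bear on it.

Compound 1 `CCCCc1nc(C)c(CC(=O)O)c(=O)n1Cc1ccc(-c2ccccc2-c2nnn[nH]2)cc1` with 0.13 mg/kg
Compound 2 `CCCCc1nc(C)c(CC(=O)N2CCOCC2)c(=O)n1Cc1ccc(-c2ccccc2-c2nnn[nH]2)cc1` with 0.018 mg/kg
Compound 3 `CCCCc1nc(C)c(CC(=O)N2CC(C)OC(C)C2)c(=O)n1Cc1ccc(-c2ccccc2-c2nnn[nH]2)cc1` with 0.029 mg/kg

In an in vivo functional assay on the whole organism for inhibition, with Rattus norvegicus as the target (on this read-out lower numbers stand for an effect already at smaller amounts and higher numbers for an effect only at larger amounts of compound), compound 3 at 0.029 mg/kg cannot be told apart from compound 2, and both lie clearly lower than compound 1. Compound 4 `CCCCc1nc(C)c(CCC(=O)N2CCCC2)c(=O)n1Cc1ccc(-c2ccccc2-c2nnn[nH]2)cc1` follows through (((pyrrolidin-1-yl)carbonyl)methyl in place of (2,6-dimethylmorpholin-4-yl)carbonyl on a saturated chain carbon bound to an aromatic carbon), with ((pyrrolidin-1-yl)carbonyl)methyl in place of (2,6-dimethylmorpholin-4-yl)carbonyl on a saturated chain carbon bound to an aromatic carbon. The closest evidence is one ring exchanged for another, a 1.6-fold higher number from compound 2 to compound 3 (0.21 log units; within the scatter), which stays within the scatter. The larger steps, a 7.2-fold lower number from compound 1 to compound 2 (0.86 log units; beyond the scatter) and a 4.5-fold lower number from compound 1 to compound 3 (0.65 log units; beyond the scatter), replace hydroxy, a change compound 4 does not repeat. For the measured compounds named here, no measured step lengthens the chain or introduces pyrrolidine. In this assay no change beyond the scatter is expected, the estimated step being a 1.2-fold higher number from compound 3 to compound 4 (0.08 log units; within the scatter). For compound 4 the estimated value is 0.035 mg/kg, with an expected range from 0.01 mg/kg to 0.12 mg/kg.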

Compound 4, dose for half-maximal effect: 0.206 mg/kg
Compound 4: middle estimate off by 5.9-fold (0.77 log units), on the low side; measured number above the stated range.
By their numbers in this assay, from the lowest: compounds 2 and 3 (each within the scatter of the next); then compounds 1 and 4 (each within the scatter of the next).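

In this assay, for the compounds shown here, this position proved sensitive after all: the amide ring exchange between the earlier compounds stayed within the scatter, but 2-((pyrrolidin-1-yl)carbonyl)ethyl brings a 7.1-fold higher number from compound 3 to compound 4 (0.85 log units; beyond the scatter) and an 11-fold higher number from compound 2 to compound 4 (1.06 log units; beyond the scatter). The advantage of the earlier amides over the carboxy compound does not carry over, with a 1.6-fold higher number from compound 1 to compound 4 (0.20 log units; within the scatter). Nothing in the data gives a reason for this result.

Going by these compounds, compound 4 changes the ring and the chain together, and which of the two carries the rise stays open. A (pyrrolidin-1-yl)carbonyl group on the shorter chain and a 2-((morpholin-4-yl)carbonyl)ethyl group would each separate the two changes.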